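Two measured ureas and a methoxy-pyridine analogue

The compounds below may be only part of what the source reports. "The series", "measured", "known", "first", "only" and "open" are said of these compounds alone.

Compound 1 `CSc1nc(C)nc(SC)c1NC(=O)N(Cc1ccc(Oc2ccc(F)cc2)cc1)C1CCCCCC1`: 56 nM
Compound 2 `CSc1cc(C)nc(SC)c1NC(=O)N(Cc1cccc(Oc2ccc(Br)cc2)c1)C1CCCCCC1`: 73 nM

In an assay for inhibition of acyl-CoA:cholesterol acyltransferase (Oryctolagus cuniculus), using microsomes (on this read-out lower numbers stand for stronger inhibition and higher numbers for weaker inhibition), compound 1 gives 56 nM, the lowest of the two numbers, and compound 2 gives 73 nM, a gap that sits within the scatter of the method, so neither can be called the stronger. Compound 3 `COc1cc(C)nc(OC)c1NC(=O)N(Cc1ccc(Oc2ccc(F)cc2)cc1)C1CCCCCC1` differs from compound 1 by a group of 11 heavy atoms (8 carbon, 1 nitrogen, 2 oxygen; one six-membered aromatic ring with 1 hetero atom) in place of a group of 11 heavy atoms (7 carbon, 2 nitrogen, 2 sulfur; one six-membered aromatic ring with 2 hetero atoms), on an amide-type nitrogen. Going by the values given here, no measured pair shows this kind of exchange, so the size of the step is uncertain; a moderate move toward a higher number in this assay is expected, the step of a 2.7-fold higher number from compound 1 to compound 3 (0.43 log units; beyond the scatter). Compound 3 is therefore expected to give about 150 nM, within a range of 50 nM to 600 nM.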

Compound 3, half-maximal inhibitory concentration: 33 nM
Beside the measured number, compound 3's estimate is 4.5-fold (0.66 log units) above it, and the stated range ends above it.
By their numbers in this assay, from the lowest: compounds 3, 1 and 2 (each within the scatter of the next, the first and the last beyond it).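

In this assay, the exchange on the amide-type nitrogen gives a 1.7-fold lower number from compound 1 to compound 3 (0.23 log units; within the scatter). The group with one ring hetero atom and two oxygen atoms therefore reads the same, within the scatter, as the group with two ring hetero atoms and two sulfur atoms. Nothing measured here accounts for this result.

As far as these compounds go, the ring atoms and the oxygen-for-sulfur exchange change together in this single step, so their separate contributions remain open. Also open, from the compounds shown here alone, is what an amine or a longer alkyl chain in that group would give.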